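A cyclohexyl group on the amide nitrogen of compound 2

A few compounds are considered here, and "the series" means these few. Any claim that something is new, unique, unknown or untested is made for them only; others in the source may bear on it.

In a functional assay on A549 cells (Homo sapiens) for antiproliferative activity, read by MTT assay, with a stated time of 72 h (a higher number here means a weaker inhibitor, a lower number a stronger inhibitor), compound 2 (`COc1ncc(-c2ccc3c(c2)NC(=O)CO3)cc1NS(=O)(=O)c1ccc(F)cc1`) gives 8070 nM and holds the lower of the two numbers available. Compound 3 (`COc1ccc(N2C(=O)COc3ccc(-c4cnc(Cl)c(NS(=O)(=O)c5ccc(F)cc5)c4)cc32)cc1`) gives 30400 nM as its nearest neighbour, higher by a gap beyond the usual scatter. Compound 1 (`COc1ccc(N2C(=O)COc3ccc(-c4ccc(O)cc4)cc32)cc1`) returns only a limit of the assay (> 40000 nM) and no number.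

Compound 4 (`COc1ncc(-c2ccc3c(c2)N(C2CCCCC2)C(=O)CO3)cc1NS(=O)(=O)c1ccc(F)cc1`) is compound 2 with a single change (cyclohexyl in place of hydrogen on an amide-type nitrogen in a ring): cyclohexyl in place of hydrogen on an amide-type nitrogen in a ring. In this assay, going by the values given here, no measured pair isolates this change, so its size can only be judged indirectly. Compound 3 also carries a substituent on that nitrogen, though it differs from compound 2 elsewhere as well. The expectation of a moderately weaker compound rests on compound 3 and its value of 30400 nM in this comparison. The step expected is a 2.2-fold higher number from compound 2 to compound 4 (0.35 log units; beyond the scatter) and it would lie near the edge of the scatter or somewhat beyond it. For compound 4 the estimated half-maximal inhibitory concentration is 18000 nM within an expected range from 5000 nM to 40000 nM in this assay.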

Compound 4, half-maximal inhibitory concentration: 24600 nM
Compound 4: middle estimate off by 1.4-fold (0.14 log units), on the low side, and the stated range covers the measured number.
By their numbers in this assay, from the lowest: compound 2; then compounds 4 and 3 (each within the scatter of the next). At a limit, above all of these: compound 1.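

Going by these compounds alone, the pair of compound 2 and compound 4 now isolates this change directly, which none of the earlier compounds could do. In this assay, cyclohexyl in place of the amide hydrogen on the amide-type nitrogen gives a 3.0-fold higher number from compound 2 to compound 4 (0.48 log units; beyond the scatter), a modest loss that is real but not a collapse of activity, so this nitrogen accepts a six-membered carbon ring at a measurable cost. Compound 4 still returns a number, whereas compound 1 sits at a limit of the assay and gives no number: the limit of > 40000 nM in this assay, at which 1 of the 4 values shown sits.

With a single substituent at this position, the step cannot show whether the loss belongs to cyclohexyl in particular or to any replacement of the amide hydrogen, and a methyl group, a longer chain or a cyclohexyl ring carrying an amine might each give a different number. Within the data shown here, the pair also rests on the one shared core of compound 2 and compound 4, so whether the same change costs as much on another core remains open.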